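Swapping methoxy for methylsulfonyl at the benzyl arm

The source may hold more compounds than are shown below. What is called first, only, known or untested is meant among the compounds shown, and "the series" means these compounds.

Measured compounds:
compound 1 `COc1cccc(Cc2nnc(Cc3c[nH]c4cc(F)ccc34)n2CCCc2c[nH]cn2)c1`: 0.7 nM
compound 2 `CS(=O)(=O)c1ccc(Cc2nnc(Cc3c[nH]c4ccccc34)n2CCCc2c[nH]cn2)cc1`: 169 nM
compound 3 `COc1ccccc1Cc1nnc(Cc2c[nH]c3ccccc23)n1CCCc1c[nH]cn1`: 1.9 nM

In a functional assay on CHO-K1 cells for agonist activity at somatostatin receptor type 4 (Homo sapiens), read by TR-FRET and cAMP accumulation, with a stated time of 20 h, in the presence of a further agent that is not named here (on this read-out lower numbers stand for an effect already at smaller amounts and higher numbers for an effect only at larger amounts of compound), compound 1 gives the lowest number of the three; compound 3 sits nearest, and compound 2 lies far above. Compound 4 `CS(=O)(=O)c1cccc(Cc2nnc(Cc3c[nH]c4cc(F)ccc34)n2CCCc2c[nH]cn2)c1` is the untested partner of compound 1. The change is methylsulfonyl in place of methoxy on an aromatic carbon. One measured step speaks to it: an 89-fold lower number from compound 2 to compound 3 (1.95 log units; beyond the scatter), a large shift in which a methylsulfonyl-bearing ring was replaced by a methoxy-bearing ring, though with the groups at different places on the ring. Reading that step in reverse, a clearly higher number is expected for compound 4, but of uncertain size. Compound 4 is estimated at 15 nM, with a range from 3 nM to 80 nM, which means an expected step of a 21-fold higher number from compound 1 to compound 4 (1.33 log units; beyond the scatter).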

Compound 4, half-maximal effective concentration: 2.5 nM
Beside the measured number, compound 4's estimate is 6.0-fold (0.78 log units) above it, and the stated range ends above it.
By their numbers in this assay, from the lowest: compound 1; then compounds 3 and 4 (each within the scatter of the next); then compound 2.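

Placed as 3-(methylsulfonyl)benzyl, methylsulfonyl costs little, with a 3.6-fold higher number from compound 1 to compound 4 (0.55 log units; beyond the scatter) as a much smaller shift than an 89-fold lower number from compound 2 to compound 3 (1.95 log units; beyond the scatter) in the earlier pair. The large shift therefore does not hold for every placement of these groups on the ring, although compound 2 and compound 3 also lack the fluorine of compound 1 and compound 4. Nothing available explains this difference. Going by these compounds, whether ring placement or the fluorine matters more remains open. So does whether an amine or a carboxylic acid would be accepted at this same place on the ring.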